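Reversing the enone and swapping methoxy for methyl

A few compounds are considered here, and "the series" means these few. Any claim that something is new, unique, unknown or untested is made for them only; others in the source may bear on it.

Measured compounds in a functional assay on A549 cells (Homo sapiens) for antiproliferative activity, read by MTT assay, with a stated time of 24 h; on this read-out lower numbers stand for stronger inhibition and higher numbers for weaker inhibition:
compound 1 `COc1ccc(C(=O)/C=C/c2cc(-c3cc(OC)c(OC)c(OC)c3)n3nc(-c4ccccc4)cc3n2)cc1` gives 14600 nM
compound 2 `COc1ccc(/C=C/C(=O)c2cc(-c3ccc(OC)c(OC)c3)n3nc(-c4ccccc4)cc3n2)cc1` gives 19300 nM
compound 3 `COc1cc(-c2cc(C(=O)/C=C/c3ccc(Cl)cc3)nc3cc(-c4ccccc4)nn23)cc(OC)c1OC` gives 23800 nM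

Compound 2 sits between compound 3 and compound 1 on these numbers, and all three lie within the scatter of one another, so none can be called stronger or weaker than the rest.

Compound 4 `COc1ccc(-c2cc(/C=C/C(=O)c3ccc(C)cc3)nc3cc(-c4ccccc4)nn23)cc1OC` differs from compound 2 in one place: 2-((4-methylphenyl)carbonyl)ethenyl in place of (2-(4-methoxyphenyl)ethenyl)carbonyl on an aromatic carbon. Among the compounds with values here, the only measured step that resembles this change is a 1.6-fold higher number from compound 1 to compound 3 (0.21 log units; within the scatter), where the carbonyl and ethenyl were likewise exchanged and the para group of the outer phenyl ring was replaced at the same time; that step stayed within the scatter. Compound 1 and compound 2 differ in two places, so their values can only be read side by side.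

On that basis the step from compound 2 to compound 4 is expected to be small, with no direction beyond the scatter: a 1.0-fold lower number from compound 2 to compound 4 (0.01 log units; within the scatter). Compound 4 is therefore estimated at 19000 nM in this assay, with a likely range from 8000 nM to 45000 nM.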

Compound 4, half-maximal inhibitory concentration: 17200 nM
Beside the measured number, compound 4's estimate is 1.1-fold (0.04 log units) above it; low and high end bracket the measured number.
By their numbers in this assay, from the lowest: compounds 1, 4, 2 and 3 (each within the scatter of the next).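

In this assay, placing 2-((4-methylphenyl)carbonyl)ethenyl where (2-(4-methoxyphenyl)ethenyl)carbonyl stood gives a 1.1-fold lower number from compound 2 to compound 4 (0.05 log units; within the scatter). With a 3,4-dimethoxyphenyl group on the core, this exchange therefore stays within the scatter, as did the similar but opposite exchange in a 1.6-fold higher number from compound 1 to compound 3 (0.21 log units; within the scatter), which carried a different para group on the outer phenyl ring and a different aryl partner in the comparison. No measurement here explains this small step.

The carbonyl and ethenyl were exchanged together with the para group, so the two changes cannot be separated, and opposing contributions cannot be ruled out. As far as these compounds go, whether an amide linker at this position, or an amine on the outer phenyl ring, would move the number beyond the scatter remains open.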